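This account rests on a few compounds, and the source may have more. Where it says the series, first, only, none or still open, it means among the compounds named here.

Working notes on the series. In a functional assay on VCaP cells (Homo sapiens) for antiproliferative activity, read by propidium iodide staining, with a stated time of 96 h (on this read-out higher numbers stand for weaker inhibition and lower numbers for stronger inhibition), compound 1 `CC(O)(CSc1ccc(S(F)(F)(F)(F)F)cc1)C(=O)Nc1ccc([N+](=O)[O-])cc1C(F)(F)F` gives 26300 nM, compound 2 `CC(O)(CSc1ccc(F)cc1)C(=O)Nc1ccc(S(F)(F)(F)(F)F)cc1` gives 23000 nM and compound 3 `CC(O)(CSc1ccc(OC(F)(F)F)cc1)C(=O)Nc1ccc(S(F)(F)(F)(F)F)cc1` gives 16000 nM. The numbers of compound 1 and compound 3 both lie within the scatter of compound 2, so compound 2 holds no separate rank among the three.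

Compound 4 `CC(O)(CSc1ccc(C(F)(F)F)cn1)C(=O)Nc1ccc(S(F)(F)(F)(F)F)cc1` is reached from compound 2 by 5-(trifluoromethyl)pyridin-2-yl in place of 4-fluorophenyl on a sulfur, with 5-(trifluoromethyl)pyridin-2-yl in place of 4-fluorophenyl on a sulfur. Among the measured compounds shown here, the one measured step that bears on this is a 1.4-fold lower number from compound 2 to compound 3 (0.16 log units; within the scatter), with trifluoromethoxy in place of fluoro on an aromatic carbon, and it stays within the scatter. For the measured compounds named here, no measured compound carries the entering group, so the change of ring is untested here. No shift beyond the scatter is therefore expected in this assay, and the expected 1.2-fold lower number from compound 2 to compound 4 (0.08 log units; within the scatter) is small. Compound 4 is estimated at 19000 nM, with an expected range of 9000 nM to 40000 nM.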

Compound 4, half-maximal inhibitory concentration: 19000 nM
The estimate for compound 4 equals the measured number at the digits printed; the measured number falls inside the stated range.
By their numbers in this assay, from the lowest: compounds 3, 4, 2 and 1 (each within the scatter of the next).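

In this assay, the step shows a 1.2-fold lower number from compound 2 to compound 4 (0.08 log units; within the scatter) for a change of the whole aromatic group on this sulfur, not only of a substituent on it, with a ring nitrogen and a hydrogen-bond acceptor entering. Together with a 1.4-fold lower number from compound 2 to compound 3 (0.16 log units; within the scatter) as the other step from compound 2, this gives two different replacements of the group on this sulfur, both within the scatter, so neither step separates its compound from compound 2 on this read-out. No measurement at hand accounts for this flat response.

The ring nitrogen and the trifluoromethyl group enter together in compound 4, so an unsubstituted pyridin-2-yl on this sulfur would be needed to separate them. On these data alone, whether the response stays flat with an amine or a carboxylic acid on the ring, or with cyclohexyl in place of the aromatic ring, remains open.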